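The compounds below may be only part of what the source reports. "The series", "measured", "known", "first", "only" and "open" are said of these compounds alone.

Measured:
compound 1 `Nc1nc2cc(-c3nn(CCCCCCCCCC(=O)NO)c4ncnc(N)c34)ccc2o1`: 98.2%
compound 2 `Nc1ncnc2c1c(-c1cnc3[nH]ccc3c1)nn2CCCCCCCCCC(=O)NO`: 98.3%

In an assay on isolated protein for inhibition of protein deacetylase HDAC6 (Homo sapiens), with a stated time of 15 min, tested at 1 uM (on this read-out higher numbers stand for more inhibition at the one concentration tested (going by the name of the read-out) and lower numbers for less inhibition), compound 1 gives the lower of the two numbers, with compound 2 nearest, a number 0.1 percentage points higher from compound 1 to compound 2 (within the scatter); the two are not separable. That one step, a swap of the aromatic group on the core, says nothing about the chain. Compound 3 `Nc1nc2cc(-c3nn(CCCCC(=O)NO)c4ncnc(N)c34)ccc2o1` carries the change (hydroxycarbamoyl in place of 5-(hydroxycarbamoyl)pentyl on a saturated chain carbon, four bonds along the chain from an aromatic nitrogen). Within the data shown here, no measured step bears on this shortening of the linker, so the expectation rests on the structures alone and is uncertain. Compound 3 is estimated at 70%, range 35% to 97%, an expected step of a number 28.2 percentage points lower from compound 1 to compound 3 (beyond the scatter), downward.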

Compound 3, a percentage reported as inhibition, at one concentration (the size of the read-out at that concentration, not a potency): 95.1%
Beside the measured number, compound 3's estimate is 25.1 percentage points below it; the range from low to high includes it.
By their numbers in this assay, from the lowest: compounds 3, 1 and 2 (each within the scatter of the next).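

In this assay, hydroxycarbamoyl in place of 5-(hydroxycarbamoyl)pentyl on a saturated chain carbon, four bonds along the chain from an aromatic nitrogen, gives a number 3.1 percentage points lower from compound 1 to compound 3 (within the scatter) and so leaves the two compounds not separable. At this one concentration, the read-out therefore does not distinguish the shorter chain of compound 3 from the longer chain of compound 1. No available evidence accounts for this result.

Still open, going by these compounds, is how a carboxylic acid in place of the hydroxycarbamoyl end group would read. On these data alone, a chain shorter than that of compound 3 also remains open.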